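Moving the Chlorine on a Urea-Linked Phenyl Ring

The source may hold more compounds than are shown below. What is called first, only, known or untested is meant among the compounds shown, and "the series" means these compounds.

Compound 2 `O=C(Nc1cccc(CNc2ncnc3ccccc23)c1)Nc1ccccc1Cl` gives 18000 nM in a functional assay on A549 cells (Homo sapiens) for antiproliferative activity, read by MTT assay (a higher number here means a weaker inhibitor, a lower number a stronger inhibitor), the lowest of the two numbers, though its neighbour compound 1 `O=C(Nc1cccc(CNc2ncnc3ccccc23)c1)Nc1ccccc1F` at 26100 nM lies within the scatter, so the two cannot be ordered. Going by the values given here, the only measured step, a 1.5-fold lower number from compound 1 to compound 2 (0.16 log units; within the scatter), exchanges one halogen for another. Compound 3 `O=C(Nc1cccc(Cl)c1)Nc1cccc(CNc2ncnc3ccccc23)c1` instead keeps the chlorine and relocates it: 3-chlorophenyl in place of 2-chlorophenyl on an amide-type nitrogen. Among the compounds with values here, no measured step bears on such a relocation, so nothing beyond the scatter is expected in this assay, and the step of no change at the digits printed from compound 2 to compound 3 (within the scatter) is estimated to be flat. Compound 3 is therefore expected to give about 18000 nM, within 6000 nM to 54000 nM.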

Compound 3, half-maximal inhibitory concentration: > 50000 nM
Compound 3: no number, only a limit; the forecaster's own chance of this, stated with the estimate: 15%; middle value at least 2.7-fold (0.44 log units) away from the limit.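

Moving the chlorine, with 3-chlorophenyl in place of 2-chlorophenyl, brings an at least 2.7-fold higher number from compound 2 to compound 3 (0.44 log units; beyond the scatter), so the site of the halogen on this ring can matter where the exchange of one halogen for another showed nothing beyond the scatter. The change from the fluoro compound brings an at least 1.9-fold higher number from compound 1 to compound 3 (0.28 log units; that floor lies within the scatter), which alone does not settle that comparison. In this assay compound 3 gives > 50000 nM, a limit and not a number: the limit of > 50000 nM in this assay, at which 1 of the 3 values shown sits.

Going by these compounds, how far compound 3 lies past that limit stays open, and so does the full size of both steps. Also open, on these data alone, is how a methoxy group or an amine in place of the chlorine would read.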